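The source may report more compounds than this note shows. Statements on the series, on what has been measured and on what is new or still open speak of the compounds shown alone.

Compound 3 `Cc1ccc(OCC(=O)N(Cc2cccs2)c2c(C)n[nH]c2C)cc1` carries 3,5-dimethyl-1H-pyrazol-4-yl on an amide-type nitrogen. In an assay on HEK293 cells for agonist activity at transient receptor potential cation channel subfamily M member 8 (Homo sapiens), read by fluorescence and calcium flux, with a stated time of 15 min (a higher number here means that more compound is needed for the effect, a lower number that less compound is needed), compound 3 gives 0.3 nM. That number sits within the usual scatter of compound 2 `Cc1ccc(OCC(=O)N(Cc2cccs2)c2ccn[nH]2)cc1`, which in this assay gives 0.2 nM, and far from compound 1 `Cc1ccc(OCC(=O)N(Cc2cccs2)CC(C)C)cc1`, which in this assay gives 900 nM. Compound 4 `COCCN(Cc1cccs1)C(=O)COc1ccc(C)cc1` differs from compound 3 in one place: 2-methoxyethyl in place of 3,5-dimethyl-1H-pyrazol-4-yl on an amide-type nitrogen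

The measured steps that bear on this change are the two in which a pyrazole took the place of isobutyl on the same nitrogen: a 3000-fold lower number from compound 1 to compound 3 (3.48 log units; beyond the scatter) and a 4500-fold lower number from compound 1 to compound 2 (3.65 log units; beyond the scatter). Both ran the same way, and exchanging one pyrazole for the other barely moved the number, a 1.5-fold higher number from compound 2 to compound 3 (0.18 log units; within the scatter). Compound 4 goes in the opposite direction, from the ring back to a chain, here 2-methoxyethyl. Within the data shown here, the chain is not isobutyl, so no measured step tells exactly how far the number should move, but a large rise toward the value of compound 1 is expected. For compound 4 the step is expected to be a 2000-fold higher number from compound 3 to compound 4 (3.30 log units; beyond the scatter). Compound 4 is therefore estimated at 600 nM, with a range of 100 nM to 5000 nM.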

Compound 4, half-maximal effective concentration: 400 nM
For compound 4 the middle estimate is 1.5-fold (0.18 log units) above the measured one, and the stated range covers the measured number.
By their numbers in this assay, from the lowest: compounds 2 and 3 (each within the scatter of the next); then compound 4; then compound 1.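

In this assay the exchange of ring for chain on the amide-type nitrogen can now be read directly, as a 1300-fold higher number from compound 3 to compound 4 (3.12 log units; beyond the scatter) and as a 2000-fold higher number from compound 2 to compound 4 (3.30 log units; beyond the scatter), so both pyrazoles stand far from 2-methoxyethyl, a group with no ring and 0 hydrogen-bond donors. The two chains lie much closer together, with a 2.3-fold lower number from compound 1 to compound 4 (0.35 log units; beyond the scatter), which shows that exchanging isopropyl for methoxymethyl on the saturated chain carbon moves the number only modestly, while for these four compounds the large gap runs between the pyrazoles and the chains. Nothing given here accounts for that gap.

The compounds shown leave open whether the gap follows the aromatic ring itself or the hydrogen on the pyrazole nitrogen, since both leave together in each large step. A phenyl ring or a 1-methylpyrazol-5-yl group on the same nitrogen would pull these two apart, and a chain ending in an amine or a carboxylic acid would show how far the number can move among chains at this position.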